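Adding a methyl to the short chain

This account rests on a few compounds, and the source may have more. Where it says the series, first, only, none or still open, it means among the compounds named here.

Among the compounds with values here, in a functional assay on SW1573 cells (Homo sapiens) for antiproliferative activity, read by sulforhodamine B assay, with a stated time of 48 h (on this read-out lower numbers stand for stronger inhibition of growth and higher numbers for weaker inhibition of growth), compound 2 `CCCC(C#CC(=O)OC)O/C=C/C(=O)OC` gives 320 nM, the lower of the two numbers so far, while compound 1 `CCCCCCC(C#CC(=O)OC)O/C=C/C(=O)OC` gives 3300 nM. Compound 3 `CCC(C)C(C#CC(=O)OC)O/C=C/C(=O)OC` differs from compound 2 as follows: methyl in place of hydrogen on a saturated chain carbon bound to two saturated chain carbons. This places methyl in place of hydrogen on a saturated chain carbon bound to two saturated chain carbons. Within the data shown here, the only measured step bearing on this is a 10-fold lower number from compound 1 to compound 2 (1.01 log units; beyond the scatter), a large one, with hydrogen in place of propyl. Methyl is a smaller addition than propyl, so a modest rise is expected in this assay. The estimated step is a 1.7-fold higher number from compound 2 to compound 3 (0.24 log units; within the scatter). For compound 3 the expected value is 550 nM, with an estimated range of 200 nM to 1600 nM.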

Compound 3, concentration for 50% growth inhibition: 910 nM
Compound 3: middle estimate off by 1.7-fold (0.22 log units), on the low side; measured number inside the range.
By their numbers in this assay, from the lowest: compound 2; then compound 3; then compound 1.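

In this assay, the methyl on the saturated chain carbon bound to two saturated chain carbons is not silent: it gives a 2.8-fold higher number from compound 2 to compound 3 (0.45 log units; beyond the scatter). Sec-butyl in place of hexyl gives a 3.6-fold lower number from compound 1 to compound 3 (0.56 log units; beyond the scatter), so compound 3 recovers only part of the ground that separates compound 1 from compound 2, and propyl keeps the lowest number of the three. Nothing at hand accounts for either step.

Open, from the compounds shown here alone, is whether an ethyl or isopropyl chain would fall lower than propyl on this read-out. Also open, going by these compounds, is how an amine or a carboxylic acid at the chain end would read.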